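The compounds below may be only part of what the source reports. "The series", "measured", "known", "first", "only" and "open" are said of these compounds alone.

Of the compounds shown here, two built on one shared core have been measured. Compound 1 `CCCCOC(=O)CCCc1cc(CN2CCCC2)c(O)c(CN2CCCC2)c1` gives 0.33 ug/mL in a functional assay for inhibition, with Cavia porcellus as the target; a higher number here means that more compound is needed for the effect, a lower number that less compound is needed. Compound 2 `CC(C)COC(=O)c1cc(CN2CCCC2)c(O)c(CN2CCCC2)c1` gives 2.3 ug/mL in this assay, the higher of the two numbers, and the gap to compound 1 lies beyond the usual scatter. Compound 3 `O=C(O)CCc1cc(CN2CCCC2)c(O)c(CN2CCCC2)c1` is not yet measured. It differs from compound 2 in a single place: 2-carboxyethyl in place of isobutoxycarbonyl on an aromatic carbon. For the measured compounds named here, no measured pair shows this exact change, so its effect cannot be read from a measured step. Going by the values given here, the only guide is that compound 1, which also carries a chain ending in a carbonyl group, gives 0.33 ug/mL, while compound 2 with its ester gives 2.3 ug/mL. Compound 3 is expected to give a slightly higher number, a step of a 1.7-fold higher number from compound 2 to compound 3 (0.24 log units; within the scatter) that may not exceed the scatter. The estimate for compound 3 is 4 ug/mL, with a range from 1.5 ug/mL to 12 ug/mL.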

Compound 3, concentration for half-maximal effect: > 1000 ug/mL
Compound 3: only a limit was reported (the forecaster's own chance of this, stated with the estimate: 10%); at least 250-fold (2.39 log units) between middle value and limit.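

In this assay, from the compounds shown here alone, compound 3 gives only a limit of the assay, > 1000 ug/mL, so its true number stays unknown. Even so, the steps are large: putting 2-carboxyethyl in place of isobutoxycarbonyl brings an at least 430-fold higher number from compound 2 to compound 3 (2.63 log units; beyond the scatter), and exchanging the (butoxycarbonyl)methyl end of the chain for carboxy brings an at least 3000-fold higher number from compound 1 to compound 3 (3.48 log units; beyond the scatter). This position therefore does not accept every group ending in a carbonyl: both esters give a measurable number, while the free carboxylic acid reaches only the limit.

Going from compound 2 to compound 3 changes both the end of the group and its distance from the ring, so the shown compounds cannot separate these two changes. Going by these compounds, a methyl ester or a primary amide on the same chain, or a longer chain ending in a carboxylic acid, remains open.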